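Fluoro to (ethylsulfonyl)amino on the pyridine of compound 3

A few compounds are considered here, and "the series" means these few. Any claim that something is new, unique, unknown or untested is made for them only; others in the source may bear on it.

Measured so far:
compound 1, `C[C@@H]1CN(c2ncccc2C(F)(F)F)CCN1C(=O)Nc1ccc(C(F)(F)F)cc1`: 17 nM in a functional assay for antagonist activity at transient receptor potential cation channel subfamily V member 1 (Homo sapiens), read by FLIPR; a higher number here means a weaker inhibitor, a lower number a stronger inhibitor
compound 2, `Cc1cccnc1-c1ccc(C(=O)Nc2ccc(Cl)cc2)cc1`: 1500 nM
compound 3, `CC(C)(C)c1ccc(NC(=O)c2ccc(-c3ncccc3F)cc2)cc1`: 3 nM

Compound 3 holds the lowest number of the three in this assay. Compound 1 stands nearest to it and compound 2 furthest; both gaps lie beyond the scatter, so compound 3 counts as the strongest inhibitor of the three measured. Compound 2 shares the biaryl amide frame of compound 3 but differs from it in more than one place, so no single step can be read from that pair; its value shows only that the frame alone does not secure a low number.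

Compound 4, `CCS(=O)(=O)Nc1cccnc1-c1ccc(C(=O)Nc2ccc(C(C)(C)C)cc2)cc1`, is not yet measured. It differs from compound 3 by (ethylsulfonyl)amino in place of fluoro on an aromatic carbon. Within the data shown here, no measured pair isolates this change, so the expectation rests on compound 3 alone and on the wide spread seen across compounds 1 to 3. A moderate rise in the number is expected, the step from compound 3 to compound 4 being estimated at a 6.7-fold higher number from compound 3 to compound 4 (0.82 log units; beyond the scatter). Compound 4 is therefore expected at 20 nM, with a range from 3 nM to 150 nM.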

Compound 4, half-maximal inhibitory concentration: 49 nM
Compound 4: the middle estimate sits 2.5-fold (0.39 log units) below what was measured; low and high end bracket the measured number.
By their numbers in this assay, from the lowest: compound 3; then compound 1; then compound 4; then compound 2.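

In this assay, among these compounds, this is the first step that isolates a change on an aromatic carbon ortho to a large group and two atoms from the ring nitrogen: a 16-fold higher number from compound 3 to compound 4 (1.21 log units; beyond the scatter), a large rise on replacing fluoro with (ethylsulfonyl)amino. The earlier compounds shown here gave only a broad spread, whereas this pair puts a size on one change at one position. Compound 4 still gives a measured 49 nM with 6 heavy atoms in place of 1, so the position accepts this much larger group at a clear cost to the number, and no data here bear on the reason for that rise.

From the compounds shown here alone, whether the rise belongs to the sulfonyl part, the amide-type hydrogen or the ethyl chain stays open, and a plain amine, a methyl in place of the ethyl, or a longer chain at this position would begin to separate these. Also open, going by these compounds, is whether the same change would produce a step of similar size with the other end of the molecule altered, as in the chloro-bearing anilide of compound 2.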